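A few compounds are considered here, and "the series" means these few. Any claim that something is new, unique, unknown or untested is made for them only; others in the source may bear on it.

The three measured compounds share one core and differ only in the group on the benzylic ring. Compound 1 `COc1cc(OC)c(/C=C/S(=O)(=O)Cc2cc(OC)c(OC)c(OC)c2)c(OC)c1` carries a trimethoxyphenyl there; in a functional assay on BT-20 cells (Homo sapiens) for antiproliferative activity, read by trypan blue exclusion (a higher number here means a weaker inhibitor, a lower number a stronger inhibitor), compound 1 gives only a limit, > 20000 nM, and no number. Compound 2 `COc1cc(OC)c(/C=C/S(=O)(=O)Cc2ccc(Cl)cc2)c(OC)c1` carries a chloro group and gives 10000 nM in this assay, while compound 3 `COc1cc(OC)c(/C=C/S(=O)(=O)Cc2ccc([N+](=O)[O-])cc2)c(OC)c1` carries a nitro group and gives 15000 nM. Among the two numbers known, compound 3 has the higher one, yet the step of a 1.5-fold higher number from compound 2 to compound 3 (0.18 log units; within the scatter) lies within the scatter, so the two compounds cannot be ranked. Compound 4 `COc1cc(OC)c(/C=C/S(=O)(=O)Cc2ccc(C#N)cc2)c(OC)c1` is the next member: cyano in place of nitro on an aromatic carbon, on an aromatic carbon of a six-membered ring of carbon only, para to a large group. For the measured compounds named here, the only measured step that bears on it, from chloro to nitro, changed the number by less than the scatter, so no step beyond the scatter is expected in this assay. Compound 4 is therefore expected to give about 12000 nM, between 5000 nM and 30000 nM. For compound 4 the estimated step is a 1.3-fold lower number from compound 3 to compound 4 (0.10 log units; within the scatter).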

Compound 4, half-maximal inhibitory concentration: 12500 nM
Estimate against measurement, compound 4: 1.0-fold (0.02 log units) below; the range from low to high includes it.
By their numbers in this assay, from the lowest: compounds 2, 4 and 3 (each within the scatter of the next). At a limit, above all of these: compound 1.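

In this assay, replacing nitro with cyano on this aromatic carbon, para to a large group, leaves the result within the scatter: a 1.2-fold lower number from compound 3 to compound 4 (0.08 log units; within the scatter), and from the chloro compound the outcome is the same, a 1.3-fold higher number from compound 2 to compound 4 (0.10 log units; within the scatter). All three exchanges among chloro, nitro and cyano at this place now lie within the scatter, so compound 2, compound 3 and compound 4 cannot be ranked against one another. Compound 1, which carries a trimethoxyphenyl group instead, gives only a limit and no number: the limit of > 20000 nM in this assay, at which 1 of the 4 values shown sits.

The compounds shown leave open whether any group at this place can move the number beyond the scatter, as an amine, a carboxylic acid or a longer chain might. They also leave open whether a change elsewhere on the shared core would have a larger effect than these exchanges.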